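The source may report more compounds than this note shows. Statements on the series, on what has been measured and on what is new or still open speak of the compounds shown alone.

Among the compounds with values here, in a physicochemical assay for solubility, with a stated time of 3 days, at pH 7 (on this read-out higher numbers stand for higher solubility and lower numbers for lower solubility), two compounds on a shared core have numbers so far. Compound 1 (`NC(=O)c1ccc2[nH]c(-c3ccc(OCCC4CCCCN4Cc4ccccc4)cc3)nc2c1`) gives 155000 nM and compound 2 (`COc1ccc(CN2CCCCC2CCOc2ccc(-c3nc4cc(C(N)=O)ccc4[nH]3)cc2)cc1`) gives 84000 nM on the same scale, which places compound 2 within the scatter of compound 1. Compound 3 (`NC(=O)c1ccc2[nH]c(-c3ccc(OCCC4CCCCN4Cc4ccc(Cl)cc4)cc3)nc2c1`) departs from compound 2 at one place, by the difference chloro in place of methoxy on an aromatic carbon at a position para to a large group, so that 4-methoxybenzyl becomes 4-chlorobenzyl. Within the data shown here, one measured step bears on this change, namely a 1.8-fold lower number from compound 1 to compound 2 (0.27 log units; within the scatter) for methoxy in place of hydrogen on an aromatic carbon. Among the measured compounds shown here, that step stays inside the scatter, and no measured compound carries chloro. No step beyond the scatter is therefore expected in this assay for this exchange. The step expected is a 1.2-fold lower number from compound 2 to compound 3 (0.08 log units; within the scatter) on this estimate. For compound 3 the estimated value is 70000 nM with an expected range from 25000 nM to 170000 nM for the coming measurement.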

Compound 3, solubility: 115000 nM
Estimate against measurement, compound 3: 1.6-fold (0.22 log units) below; the measured number falls inside the stated range.
By their numbers in this assay, from the lowest: compounds 2, 3 and 1 (each within the scatter of the next).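

In this assay, the exchange of 4-methoxybenzyl for 4-chlorobenzyl comes out as a 1.4-fold higher number from compound 2 to compound 3 (0.14 log units; within the scatter), and chloro set against hydrogen at the same aromatic carbon comes out as a 1.3-fold lower number from compound 1 to compound 3 (0.13 log units; within the scatter). Hydrogen, methoxy and chloro have now all been read at this one place, para to a large group, and all three compounds lie within the scatter of one another, whereas the earlier pair covered only hydrogen and methoxy. Across these three compounds, then, a group with an oxygen and a group with a halogen at this place give no step that can be told from the scatter, and no measurement shown offers an explanation for these numbers or links them to any property of the groups.

The compounds shown leave open whether an amine or a carboxylic acid on this aromatic carbon would also stay within the scatter of compound 1. They also leave open whether a longer chain in place of methoxy would give a step beyond the scatter in this assay.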